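The compounds below may be only part of what the source reports. "The series", "measured", "known", "first", "only" and "open" are said of these compounds alone.

Series notes. Compound 1 `NS(=O)(=O)c1ccc(/N=C2\NC(=O)/C(=C3/C(=O)Nc4ccccc43)S2)cc1`, compound 2 `Cc1ccc2c(c1)/C(=C1/S/C(=N/c3ccc(S(N)(=O)=O)cc3)NC1=O)C(=O)N2` and compound 3 `Cc1cc(C)c2c(c1)/C(=C1/S/C(=N/c3ccc(S(N)(=O)=O)cc3)NC1=O)C(=O)N2` share one core and differ only in methyl in place of hydrogen on an aromatic carbon of the fused six-membered carbon ring. In a functional assay on MCF7 cells (Homo sapiens) for antiproliferative activity, read by MTT assay (a higher number here means a weaker inhibitor, a lower number a stronger inhibitor), compound 1 gives only a limit, > 200000 nM. In this assay compound 2 likewise gives a limit, > 200000 nM. Compound 3 also returns a limit, > 200000 nM. The step that the two limits leave unreadable from compound 1 to compound 2 and the step that the two limits leave unreadable from compound 2 to compound 3 cannot be sized because of the limit of > 200000 nM in this assay, at which 3 of the 3 values shown sit. Compound 4 `NS(=O)(=O)c1ccc(/N=C2\NC(=O)/C(=C3/C(=O)Nc4ccc(F)cc43)S2)cc1` differs from compound 2 by fluoro in place of methyl on an aromatic carbon. Both measured steps touch this same ring, yet neither has a readable size, so no step beyond the scatter can be predicted in either direction. Compound 4 is expected to sit at the same limit, estimated at 300000 nM with a range from 100000 nM to 1000000 nM. The expected step is a step that the limit leaves unreadable from compound 2 to compound 4.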

Compound 4, half-maximal inhibitory concentration: 20500 nM
Estimate against measurement, compound 4: 15-fold (1.17 log units) above, and the stated range ends above it.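

In this assay, within the data shown here, fluoro at this position gives the first readable change on this ring: an at least 9.7-fold lower number from compound 2 to compound 4 (0.98 log units; beyond the scatter), and an at least 9.7-fold lower number from compound 1 to compound 4 (0.98 log units; beyond the scatter). Compound 4 is the only compound shown with a measured value rather than a limit, whereas methyl at the same place in compound 2 leaves the reading at the limit. Both steps are only minimum sizes, because compound 1 and compound 2 stand at a limit: the limit of > 200000 nM in this assay, at which 3 of the 4 values shown sit.

From the compounds shown here alone, whether chloro, bromo, methoxy or an amine at this position would also give a measurable value stays open. Going by these compounds, the full size of both steps also stays open.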